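The source may hold more compounds than are shown below. What is called first, only, known or untested is meant among the compounds shown, and "the series" means these compounds.

In a functional assay on HT-29 cells (Homo sapiens) for inhibition, read by sulforhodamine B assay (on this read-out higher numbers stand for weaker inhibition and lower numbers for stronger inhibition), compound 1 `COC(=O)CC/C(C)=C/Cc1c(OC)c(C)c2c(c1OCC#CCN1CCN(c3ccc(C#N)cc3)CC1)C(=O)OC2` gives > 50000 nM as a limit of the assay and not as a number. Compound 2 `COC(=O)CC/C(C)=C/Cc1c(OC)c(C)c2c(c1OCC#CCN1CCN(Cc3ccc(Cl)cc3)CC1)C(=O)OC2` gives > 50000 nM as a limit too. Compound 1 thus has only the limit of > 50000 nM in this assay, at which 2 of the 2 values shown sit, to stand on. Among the compounds with values here, the one measured step is a step that the two limits leave unreadable from compound 1 to compound 2 and offers no size to carry over to another change on that amine nitrogen. Compound 3 `COC(=O)CC/C(C)=C/Cc1c(OC)c(C)c2c(c1OCC#CCN1CCN(c3ccccc3OC)CC1)C(=O)OC2` keeps the core of compound 1 and takes 2-methoxyphenyl in place of 4-cyanophenyl on an amine nitrogen in a ring, with 2-methoxyphenyl in place of 4-cyanophenyl on an amine nitrogen in a ring as the counted difference. With no readable step to go on, no step beyond the scatter is expected in this assay and another report at the limit is likely. The estimated step is a number no higher from compound 1 to compound 3 (the limit leaves the size open) on this reasoning. For compound 3 the estimate is 50000 nM with 20000 nM to 100000 nM as the expected range.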

Compound 3, half-maximal inhibitory concentration: > 50000 nM
Compound 3: a limit, no number (the forecaster's own chance of this, stated with the estimate: 70%); the middle value lies on the limit itself.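

Within the data shown here, compound 3, like compound 1 and compound 2, stays at a limit of the assay, so no step among the three can be read in this assay: the limit of > 50000 nM in this assay, at which 3 of the 3 values shown sit. The compounds shown leave open whether any group on that amine nitrogen would give a measurable number.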